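This account rests on a few compounds, and the source may have more. Where it says the series, first, only, none or still open, it means among the compounds named here.

Measured so far:
compound 1, `Cc1ccc2[nH]c(C(=O)N[C@H]3CN(S(=O)(=O)c4ccccc4)C[C@@H]3C(=O)N[C@H]3CCCN(C)C3)cc2c1`, 23 uL/min
compound 2, `O=C(N[C@H]1CN(S(=O)(=O)c2ccccc2)C[C@@H]1C(=O)NC[C@@H]1CCCN1)c1cc(-c2ccccc2Cl)on1`, 22 uL/min
compound 3, `CN(C(=O)[C@H]1CN(S(=O)(=O)c2ccccc2)C[C@@H]1NC(=O)c1cc(-c2ccccc2Cl)on1)[C@H]1CCCNC1`, 5.8 uL/min

In an ADME assay on cells (Hepatocyte, Rattus norvegicus) for metabolic stability (on this read-out higher numbers stand for fast clearance and lower numbers for slow clearance), compound 3 stands lowest of the three. Within the data shown here, the only measured step, a 3.8-fold lower number from compound 2 to compound 3 (0.58 log units; beyond the scatter), is modest and ends at compound 3. Compound 4 `CN1CCC[C@H](NC(=O)[C@H]2CN(S(=O)(=O)c3ccccc3)C[C@@H]2NC(=O)c2cc(-c3ccccc3Cl)on2)C1` has the same atoms as compound 3, joined differently: a group of 8 heavy atoms (6 carbon, 2 nitrogen; one six-membered non-aromatic ring with 1 hetero atom) in place of a group of 8 heavy atoms (6 carbon, 2 nitrogen; one six-membered non-aromatic ring with 1 hetero atom), on a carbonyl carbon. Among the measured compounds shown here, no measured step covers this rearrangement. Compound 1 carries the same (1-methylpiperidin-3-yl)amino group on a core with a different acyl part and gives a clearly higher number than compound 3, which suggests a moderate upward move in this assay, though the other end of the molecule also differs. Compound 4 is therefore expected to give 12 uL/min, with a range from 5 uL/min to 30 uL/min. The expected step is a 2.1-fold higher number from compound 3 to compound 4 (0.32 log units; beyond the scatter).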

Compound 4, intrinsic clearance in a liver preparation (reported as CLH), per the amount of preparation that the assay uses: 31 uL/min
The estimate for compound 4 lay 2.6-fold (0.41 log units) below the measured number; measured number outside the range, above it.
By their numbers in this assay, from the lowest: compound 3; then compounds 2, 1 and 4 (each within the scatter of the next).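

With no atom gained or lost, putting the (1-methylpiperidin-3-yl)amino group on the carbonyl carbon gives a 5.3-fold higher number from compound 3 to compound 4 (0.73 log units; beyond the scatter) in this assay, so this position responds to how the atoms are joined, not only to which atoms are present. Two other changes, a 1.4-fold higher number from compound 2 to compound 4 (0.15 log units; within the scatter) and a 1.3-fold higher number from compound 1 to compound 4 (0.13 log units; within the scatter), leave the number within the scatter, so among these four compounds only compound 3 stands apart. Nothing measured here gives a reason for this. Still open, on these data alone, is what a 1-ethylpiperidin-3-yl or a 1-methylpiperidin-4-yl group would give on this carbonyl carbon.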